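Methoxy in Place of Methyl: Expecting Compound 3

The source may report more compounds than this note shows. Statements on the series, on what has been measured and on what is new or still open speak of the compounds shown alone.

This account follows a single change on a shared core. In a functional assay, with a stated time of 150 min, tested at 35 ug/mL (a higher number here means a stronger effect of the compound at the concentration tested, a lower number a weaker effect), compound 1 `COC(=O)c1c(Nc2ccccc2)sc(C(=O)c2ccc(OC)cc2)c1C` gives 63%, whereas compound 2 `COC(=O)c1c(Nc2ccc(C)cc2)sc(C(=O)c2ccc(OC)cc2)c1C` is reported only as "not active" (no number reported). Compound 2 therefore stands without a number in this assay: it is recorded as showing no effect at the tested concentration, and that is all that is known of it. Compound 3 `COC(=O)c1c(Nc2ccc(OC)cc2)sc(C(=O)c2ccc(OC)cc2)c1C` has not yet been tested in this assay. The change from compound 2 to compound 3 is methoxy in place of methyl on an aromatic carbon. Among the measured compounds shown here, no measured step of this kind is available, so the size of the step cannot be read from a neighbouring pair; what can be said is that compound 1 gives 63% in this assay while compound 2 gives "not active" (no number reported). The expected step in this assay is small, upward if anything, and quite possibly not beyond the scatter. Compound 3 is expected to give about 20% in this assay, within a range from 0% to 55%, with a real chance that it is again reported without a number.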

Compound 3, a percentage reported as activity, at one concentration (the size of the read-out at that concentration, not a potency): 25.1%
Compound 3: the middle estimate sits 5.1 percentage points below what was measured; measured number inside the range.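

In this assay compound 3 gives 25.1%, so methoxy on this aromatic carbon, para to a large group, leaves an effect that can be put as a number, whereas methyl at the same place in compound 2 left only the record "not active" (no number reported). Set against the unsubstituted ring of compound 1, methoxy in place of hydrogen gives a number 37.9 percentage points lower from compound 1 to compound 3 (beyond the scatter), which puts a size on the loss for at least one group at this position and shows that hydrogen is the better of the two where numbers exist. On these data alone, the step between compound 2 and compound 3 itself cannot be read, as compound 2 has no number, so how far methoxy really differs from methyl remains unknown.

Nothing measured here speaks to why either group lowers the read-out, and no cause can be offered for the difference between them. The compounds shown also leave open whether a hydroxyl, an amine or a chlorine at this same place would keep the effect of compound 1 or lose it as methoxy does.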